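A few compounds are considered here, and "the series" means these few. Any claim that something is new, unique, unknown or untested is made for them only; others in the source may bear on it.

Compound 1 `Cn1ncc(Cl)c1-c1cc(C(=O)N[C@@H]2CN[C@H](CCn3cncn3)C[C@H]2c2ccc(Cl)c(Cl)c2)oc1Cl`: 560 nM
Compound 2 `Cn1ncc(Cl)c1-c1cc(C(=O)N[C@@H]2CN[C@H](CCN3CCCC3)C[C@H]2c2ccc(Cl)c(Cl)c2)oc1Cl`: 1940 nM
Compound 3 `Cn1ncc(Cl)c1-c1cc(C(=O)N[C@@H]2CN[C@H](CC(=O)NC3CCC3)C[C@H]2c2ccc(Cl)c(Cl)c2)oc1Cl`: 430 nM

In a functional assay on HCT-116 cells (Homo sapiens) for antiproliferative activity, read by sulforhodamine B assay, with a stated time of 72 h (on this read-out lower numbers stand for stronger inhibition and higher numbers for weaker inhibition), compound 3 gives the lowest of the three numbers shown, though its distance from compound 1 stays within the scatter (a 1.3-fold lower number from compound 1 to compound 3 (0.11 log units; within the scatter)), while its distance from compound 2 goes beyond it (a 4.5-fold lower number from compound 2 to compound 3 (0.65 log units; beyond the scatter)). Compound 4 `Cn1ncc(Cl)c1-c1cc(C(=O)N[C@@H]2CN[C@H](CC(O)CO)C[C@H]2c2ccc(Cl)c(Cl)c2)oc1Cl` differs from compound 3 in one place: 1,2-dihydroxyethyl in place of cyclobutylcarbamoyl on a saturated chain carbon bound to a saturated ring carbon. Within the data shown here, both measured steps change the group on this same chain carbon, and neither exceeds a modest size, yet no measured compound carries anything resembling the entering group. The step of a 2.1-fold higher number from compound 3 to compound 4 (0.32 log units; beyond the scatter) is therefore expected to be small to modest and upward. Compound 4 is accordingly estimated at 900 nM, with a range from 300 nM to 2700 nM.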

Compound 4, half-maximal inhibitory concentration: 1110 nM
Estimate against measurement, compound 4: 1.2-fold (0.09 log units) below; the measured number falls inside the stated range.
By their numbers in this assay, from the lowest: compounds 3, 1, 4 and 2 (each within the scatter of the next, the first and the last beyond it).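

In this assay, a group with no ring on this saturated chain carbon separates from the cyclobutylcarbamoyl group, with a 2.6-fold higher number from compound 3 to compound 4 (0.41 log units; beyond the scatter). Yet a 1.7-fold lower number from compound 2 to compound 4 (0.24 log units; within the scatter) and a 2.0-fold higher number from compound 1 to compound 4 (0.30 log units; within the scatter), so the 1,2-dihydroxyethyl group lies within the scatter of two groups that are themselves separated by more than the scatter. No measurement given here accounts for this step. The compounds shown leave open whether the cyclobutyl ring or the amide of compound 3 matters more. They also leave open how a carboxylic acid or a single hydroxyl on a longer chain would read at this carbon.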